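The compounds below may be only part of what the source reports. "The series", "measured", "known", "first", "only" and "open" are said of these compounds alone.

In a functional assay on HL-60 cells (Homo sapiens) for cytotoxicity, read by WST assay, with a stated time of 48 h (a lower number here means that less compound is needed, a higher number that more compound is needed for the effect), compound 2 `O=C1OC[C@H](Cc2cccc(O)c2)[C@H]1Cc1ccc(Cl)c(Cl)c1` gives 48000 nM, the highest of the three numbers seen so far. Compound 3 `COc1ccc(C[C@H]2COC(=O)[C@@H]2Cc2ccc(Cl)c(Cl)c2)cc1O` gives 32000 nM, and compound 1 `O=C1OC[C@H](Cc2ccccc2)[C@H]1Cc1ccc(Cl)cc1Cl` gives 19000 nM. The change to compound 4 `Cc1ccc(C[C@H]2COC(=O)[C@@H]2Cc2ccc(Cl)c(Cl)c2)cc1C` is 3,4-dimethylphenyl in place of 3-hydroxyphenyl on a saturated chain carbon bound to a saturated ring carbon. Among the compounds with values here, only one measured step touches the same ring: a 1.5-fold lower number from compound 2 to compound 3 (0.18 log units; within the scatter), which shows that adding a group on that ring hardly moved the number. Compound 1, which carries no hydroxyl on that ring, sits at a lower number than compound 2, but it also differs elsewhere, so it gives only a loose hint. The expected step is therefore small, a 1.9-fold lower number from compound 2 to compound 4 (0.28 log units; within the scatter), leaning toward a lower number. Compound 4 is estimated at 25000 nM, in a range from 8000 nM to 70000 nM.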

Compound 4, half-maximal effective concentration: 16000 nM
Estimate against measurement, compound 4: 1.6-fold (0.19 log units) above, and the stated range covers the measured number.
By their numbers in this assay, from the lowest: compounds 4, 1, 3 and 2 (each within the scatter of the next, the first and the last beyond it).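

In this assay, within the data shown here, 3,4-dimethylphenyl in place of 3-hydroxyphenyl gives a 3.0-fold lower number from compound 2 to compound 4 (0.48 log units; beyond the scatter) and is the first step on this ring to lie beyond the scatter, which the step from compound 2 to compound 3 did not. The number at this position can therefore move, if modestly, when a ring with no hydrogen-bond donor or acceptor replaces one carrying one of each. Nothing measured here explains the shift. Because the hydroxyl leaves as the two methyl groups enter, the compounds shown cannot separate those two changes. On these data alone, whether an amine or a carboxylic acid on this ring would move the number remains open.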